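Urea series: trifluoromethoxy in place of trifluoromethyl

This account rests on a few compounds, and the source may have more. Where it says the series, first, only, none or still open, it means among the compounds named here.

Compound 1 `O=C(Nc1cccc2[nH]ncc12)NC1CCOc2cc(OC(F)(F)F)ccc21`: 8 nM
Compound 2 `O=C(Nc1cccc2[nH]ncc12)NC1CCOc2c1cccc2C(F)(F)F`: 5 nM

In a functional assay for antagonist activity at transient receptor potential cation channel subfamily V member 1 (Homo sapiens), read by calcium flux (on this read-out lower numbers stand for stronger inhibition and higher numbers for weaker inhibition), compound 2 sits at the low end of the two numbers shown, yet its gap to compound 1 lies within the usual scatter, so the two are not distinguished. Compound 3 `O=C(Nc1cccc2[nH]ncc12)NC1CCOc2c(OC(F)(F)F)cccc21` differs from compound 2 by trifluoromethoxy in place of trifluoromethyl on an aromatic carbon. Among the compounds with values here, no step between measured compounds covers this change, so nothing beyond the scatter is expected in either direction. Compound 3 is therefore estimated at 8 nM, with a range from 2 nM to 30 nM. That estimate means an expected step of a 1.6-fold higher number from compound 2 to compound 3 (0.20 log units; within the scatter), inside the scatter.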

Compound 3, half-maximal inhibitory concentration: 5 nM
The estimate for compound 3 lay 1.6-fold (0.20 log units) above the measured number, within the range that was stated.
By their numbers in this assay, from the lowest: compounds 2, 3 and 1 (each within the scatter of the next).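

In this assay, trifluoromethoxy in place of trifluoromethyl on this aromatic carbon, ortho to a fused ring, gives no change at the digits printed from compound 2 to compound 3 (within the scatter). Within the data shown here, this is the only single-place step so far, and it shows that this position accepts either group, with one more hydrogen-bond acceptor by count and no separable change in the read-out. Nothing measured here bears on why the two groups read alike. On these data alone, whether an amine, a carboxylic acid or a longer alkoxy chain on this carbon would hold the number remains open. So does whether the same exchange reads alike on the core of compound 1.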